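The source may report more compounds than this note shows. Statements on the series, on what has been measured and on what is new or still open speak of the compounds shown alone.

Measured in a physicochemical assay for solubility, in phosphate buffer, measured as kinetic solubility, at pH 7.4, tested at 250 uM; a higher number here means a more soluble compound, a lower number a less soluble compound:
- compound 1 `CCCCCCNc1ccc([N+](=O)[O-])cc1S(N)(=O)=O`: 6000 nM
- compound 2 `CCCCCCCCNc1ccc(C(=O)O)cc1S(N)(=O)=O`: > 250000 nM (a limit, not a number)
- compound 3 `CN(C)S(=O)(=O)c1cc(C(=O)O)ccc1NCCC(C)(C)C`: > 250000 nM (a limit, not a number)

Compound 2 and compound 3 both stand at the limit of > 250000 nM in this assay, at which 2 of the 3 values shown sit. Compound 3 therefore has no exact number in this assay, only its limit.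

Compound 4 `COCCCCNc1ccc(C(=O)O)cc1S(=O)(=O)N(C)C` carries 2-methoxyethyl in place of tert-butyl on a saturated chain carbon, two bonds along the chain from a nitrogen on an aromatic ring.

For the measured compounds named here, no measured pair shows this change, so the expectation rests on compound 3 alone, with its limit of > 250000 nM. No change beyond the scatter is expected in this assay. The expected step is an at least 1.0-fold lower number from compound 3 to compound 4 (0.01 log units; that floor lies within the scatter). For compound 4 the estimate is 240000 nM, with an expected range of 120000 nM to 250000 nM.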

Compound 4, solubility: 247000 nM
For compound 4 the middle estimate is 1.0-fold (0.01 log units) below the measured one; the measured number falls inside the stated range.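

In this assay the step from the tert-butyl to the 2-methoxyethyl group at this position reads an at least 1.0-fold lower number from compound 3 to compound 4 (0.00 log units; that floor lies within the scatter), so it shows no change beyond the scatter. Compound 4 gives 247000 nM, the only exact number among the compounds shown that carry a carboxylic acid. Compound 3 has only a limit, so the step is no more than a floor: the limit of > 250000 nM in this assay, at which 2 of the 4 values shown sit.

The compounds shown leave open what the number becomes when an amine or an amide replaces the carboxylic acid alongside the 4-methoxybutyl chain. They also leave open whether a longer chain ending in a hydroxyl group gives a similar number.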